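Adding a nitro group to compound 3

The source may report more compounds than this note shows. Statements on the series, on what has been measured and on what is new or still open speak of the compounds shown alone.

compound 1 `O=C1/C(=C/c2cccnc2)CN(S(=O)(=O)c2ccc([N+](=O)[O-])cc2)C/C1=C\c1ccccc1F` gives 12800 nM
compound 2 `O=C1/C(=C/c2ccncc2)CNC/C1=C\c1ccccc1F` gives 8200 nM
compound 3 `O=C1/C(=C/c2ccncc2)CN(S(=O)(=O)c2ccccc2)C/C1=C\c1ccccc1F` gives 5800 nM

All three numbers come from a functional assay on HepG2 cells (Homo sapiens) for cytotoxicity, read by MTT assay, with a stated time of 24 h (a higher number here means a weaker inhibitor, a lower number a stronger inhibitor), and the next compound is judged against them. Compound 3 at 5800 nM cannot be told apart from compound 2 at 8200 nM. The gap between them lies within the scatter. Compound 1 at 12800 nM shows a higher number than compound 3, and that gap lies beyond the scatter.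

Compound 4 `O=C1/C(=C/c2ccncc2)CN(S(=O)(=O)c2ccc([N+](=O)[O-])cc2)C/C1=C\c1ccccc1F` differs from compound 3 in one place: nitro in place of hydrogen on an aromatic carbon with nitro in place of hydrogen on an aromatic carbon, which turns phenyl to 4-nitrophenyl. Among the measured compounds shown here, no measured pair shows this exact change. For the measured compounds named here, the only measured step, a 1.4-fold lower number from compound 2 to compound 3 (0.15 log units; within the scatter) for adding phenylsulfonyl on the ring nitrogen, stayed small. The 4-nitrophenyl group also appears in a compound that differs from compound 4 elsewhere, namely compound 1 at 12800 nM and this hints weakly at a higher number. A small rise is therefore expected, with a weaker inhibitor at most modestly so and possibly no change beyond the scatter. The estimate is a 1.3-fold higher number from compound 3 to compound 4 (0.11 log units; within the scatter) as the expected step. Compound 4 is estimated at 7500 nM with an expected range from 3500 nM to 16000 nM around that middle value.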

Compound 4, half-maximal inhibitory concentration: 11300 nM
Beside the measured number, compound 4's estimate is 1.5-fold (0.18 log units) below it, within the range that was stated.
By their numbers in this assay, from the lowest: compounds 3, 2, 4 and 1 (each within the scatter of the next, the first and the last beyond it).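

Among the compounds shown here, compound 4 gives the first direct reading of nitro in place of hydrogen on an aromatic carbon, para to a large group, and in this assay the result is a 1.9-fold higher number from compound 3 to compound 4 (0.29 log units; within the scatter), so the change from phenyl to 4-nitrophenyl cannot be told apart from repeat-measurement noise. With the 4-nitrophenyl group held constant, the pyridine swap gives a 1.1-fold lower number from compound 1 to compound 4 (0.05 log units; within the scatter), so pyridin-4-yl in place of pyridin-3-yl also cannot be told apart from that noise, and neither single change has a clear effect on the number in this assay. No measurement is available here that would explain either result.

With only hydrogen and nitro shown at this place on the ring, it remains open whether another group, such as an amine, a carboxylic acid or a methoxy group, would give a step beyond the scatter. On these data alone, it also remains open whether these two small steps would stay small on other cell types or with a different exposure time.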